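The compounds below may be only part of what the source reports. "The series", "measured", "known", "first", "only" and "open" are said of these compounds alone.

Measured so far:
compound 1 `CC(C)n1c(SCc2ccccc2Cl)nc2cc(NC(=O)C3CC3)ccc21`: > 10000 nM
compound 2 `COc1ccc([N+](=O)[O-])cc1CSc1nc2cc(NC(=O)C(C)(C)C)ccc2n1C(C)C`: > 10000 nM

Both compounds were tested in an assay on isolated protein for inhibition of Gonadotropin-releasing hormone receptor (Rattus norvegicus); on this read-out higher numbers stand for weaker inhibition and lower numbers for stronger inhibition. For compound 1 the value > 10000 nM is a limit of the assay and not a number. For compound 2 the value > 10000 nM is likewise a limit and not a number. Compound 2 therefore stands at the limit of > 10000 nM in this assay, at which 2 of the 2 values shown sit; no number places it relative to compound 1, and nothing separates the two beyond the fact that both sit at the limit.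

Compound 3 `CNC(=O)Nc1ccc2c(c1)nc(SCc1cc([N+](=O)[O-])ccc1OC)n2C(C)C` has not yet been measured in this assay. It differs from compound 2 in one place: methylamino in place of tert-butyl on a carbonyl carbon. Among the measured compounds shown here, no step between measured compounds exists, so the size of this change in this assay cannot be read off and can only be expected. The expectation is that compound 3 stays near the limit, with a step that the limit leaves unreadable from compound 2 to compound 3 not expected to carry it into the measurable range. The estimate for compound 3 is 15000 nM, within 3000 nM to 100000 nM, with a good chance that this assay again reports only a limit.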

Compound 3, half-maximal inhibitory concentration: > 10000 nM
Compound 3 was reported as a limit; the forecaster's own chance of this, stated with the estimate: 75%; the middle value does not contradict the limit.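

Compound 2 and compound 3 are both reported only as limits, not numbers, in this assay, so no step between them can be read: the limit of > 10000 nM in this assay, at which 3 of the 3 values shown sit.

The compounds shown leave open whether methylamino in place of tert-butyl on a carbonyl carbon alters inhibition at all, and what measurable value, if any, this series reaches in this assay.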